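This account rests on a few compounds, and the source may have more. Where it says the series, first, only, none or still open, it means among the compounds named here.

Compound 1 is `CCCCOc1ccc(C(O)C2OC(=O)c3c(OC)cc(OC)cc32)cc1`. In an ADME assay on RAW264.7 cells (Mus musculus) for cytotoxicity, read by MTT assay, with a stated time of 24 h, in the absence of a further agent (on this read-out lower numbers stand for stronger inhibition and higher numbers for weaker inhibition), compound 1 gives only a limit, > 40000 nM. Compound 2 is `CCC(C)Oc1ccc(C(O)C2OC(=O)c3c(OC)cc(OC)cc32)cc1`. In this assay compound 2 likewise gives a limit, > 40000 nM. Compound 3 is `COc1cc(OC)c2c(c1)C(C(O)c1ccc(OCc3ccc(Br)cc3)cc1)OC2=O`. Compound 3 also gives a limit in this assay, > 40000 nM.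

Compound 1 therefore stands only at a limit, and so do its two neighbours: all three values sit at the limit of > 40000 nM in this assay, at which 3 of the 3 values shown sit. The steps a step that the two limits leave unreadable from compound 1 to compound 2, a step that the two limits leave unreadable from compound 1 to compound 3 and a step that the two limits leave unreadable from compound 2 to compound 3 are thus all unreadable in size.

Compound 4 is `COc1cc(OC)c2c(c1)C(C(O)c1ccc(OCc3ccc(C)cc3)cc1)OC2=O`, differing from compound 1 by 4-methylphenyl in place of propyl on a saturated chain carbon bound to an oxygen on an aromatic ring. The step from compound 1 to compound 3 changes the same place, yet its size cannot be read. The step that the limit leaves unreadable from compound 1 to compound 4 is therefore expected to stay within the scatter, most likely ending at a limit again. Compound 4 is estimated at 60000 nM, with a range from 30000 nM to 200000 nM.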

Compound 4, half-maximal inhibitory concentration: > 40000 nM
Compound 4 gave a limit, no number; the forecaster's own chance of this, stated with the estimate: 85%; the middle value is on the limit's open side.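

Compound 4 gives only the limit > 40000 nM in this assay and its steps to compound 1, compound 2 and compound 3 cannot be read. Whether any change among these compounds shifts the read-out at all stays open: the limit of > 40000 nM in this assay, at which 4 of the 4 values shown sit.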